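The source may hold more compounds than are shown below. What is called first, only, known or untested is meant among the compounds shown, and "the series" means these compounds.

Series notes. All four compounds share one core carrying an amide-type nitrogen, and they differ only in the group on that nitrogen. Compound 1 `Cc1ccc(NC(=O)COc2ccc3cc(/C=C4/SC(=O)NC4=O)ccc3c2)cc1` carries 4-methylphenyl there; in an assay on isolated protein for inhibition of histone deacetylase 4 (Homo sapiens), with a stated time of 1 h (on this read-out higher numbers stand for weaker inhibition and lower numbers for stronger inhibition), compound 1 gives 1700 nM. Compound 2 `Cc1cccc2sc(NC(=O)COc3ccc4cc(/C=C5/SC(=O)NC5=O)ccc4c3)nc12` carries 4-methyl-1,3-benzothiazol-2-yl, and in this assay compound 2 gives 1200 nM. Compound 3 `O=C(COc1ccc2cc(/C=C3/SC(=O)NC3=O)ccc2c1)Nc1ccccn1` carries pyridin-2-yl, and in this assay compound 3 gives 17000 nM. Among these three numbers compound 1 stands second highest: the step of a 1.4-fold lower number from compound 1 to compound 2 (0.15 log units; within the scatter) is within the scatter, while a 10-fold higher number from compound 1 to compound 3 (1.00 log units; beyond the scatter) and a 14-fold higher number from compound 2 to compound 3 (1.15 log units; beyond the scatter) are beyond it.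

Compound 4 `O=C(COc1ccc2cc(/C=C3/SC(=O)NC3=O)ccc2c1)Nc1ccc(Br)c(Br)c1` has not yet been measured. Against compound 1 the change is 3,4-dibromophenyl in place of 4-methylphenyl on an amide-type nitrogen. Going by the values given here, no measured step swaps one six-membered aromatic ring of carbon only for another of the same kind; the two measured steps from compound 1 replace 4-methylphenyl with 4-methyl-1,3-benzothiazol-2-yl, a 1.4-fold lower number from compound 1 to compound 2 (0.15 log units; within the scatter), or with pyridin-2-yl, a 10-fold higher number from compound 1 to compound 3 (1.00 log units; beyond the scatter). Neither bears directly on a 3,4-dibromophenyl, so in this assay no step beyond the scatter is expected for compound 4, with somewhat more room on the weaker side given that compound 3 reaches 17000 nM. For compound 4 the estimate in this assay is 1600 nM, within 500 nM to 5000 nM, which means an expected step of a 1.1-fold lower number from compound 1 to compound 4 (0.03 log units; within the scatter).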

Compound 4, half-maximal inhibitory concentration: 4900 nM
Estimate against measurement, compound 4: 3.1-fold (0.49 log units) below, within the range that was stated.
By their numbers in this assay, from the lowest: compounds 2 and 1 (each within the scatter of the next); then compound 4; then compound 3.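

Going by these compounds alone, compound 4 gives the only step from compound 1 that keeps one six-membered aromatic ring of carbon only on the amide-type nitrogen, and in this assay that step still lies beyond the scatter, as a 2.9-fold higher number from compound 1 to compound 4 (0.46 log units; beyond the scatter) shows. Replacing 4-methylphenyl with 3,4-dibromophenyl therefore shifts the number without any change in the ring type, so this position responds to what the ring carries as well as to the ring itself. Compound 4 also fills the gap in the series, with a 4.1-fold higher number from compound 2 to compound 4 (0.61 log units; beyond the scatter) on one side and a 3.5-fold lower number from compound 3 to compound 4 (0.54 log units; beyond the scatter) on the other; no supporting data bear on what lies behind these steps.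

The compounds shown leave open whether a plain phenyl, with neither methyl nor bromine, would read closer to compound 1 or to compound 4, and whether a single bromine would give the same result as the two in 3,4-dibromophenyl. Also open, from the compounds shown here alone, is how a phenyl ring carrying an amine or a carboxylic acid would read in this assay at this amide-type nitrogen.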